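The source may hold more compounds than are shown below. What is called first, only, known or untested is meant among the compounds shown, and "the series" means these compounds.

Compound 2 `O=C(NCCO)c1cc2ccc(OCc3cccc(Br)c3)cc2oc1=O` is one of three compounds tested in a functional assay on HCT-116 cells (Homo sapiens) for cytotoxicity, read by MTT assay, with a stated time of 72 h; a higher number here means a weaker inhibitor, a lower number a stronger inhibitor. In this assay, among the measured compounds shown here, compound 2 gives 30800 nM, and it is one of only two numbers available. Its closest neighbour, compound 3 `O=C(NCCO)c1cc2ccc(OCc3ccc([N+](=O)[O-])cc3)cc2oc1=O`, gives 33400 nM in this assay, and the difference is a 1.1-fold higher number from compound 2 to compound 3 (0.04 log units; within the scatter). Compound 1 `CCCOc1ccc2cc(C(=O)NCCO)c(=O)oc2c1` gives only a limit of the assay, > 100000 nM, in this assay. Relative to that limit, the change to compound 2 is an at least 3.2-fold lower number from compound 1 to compound 2 (0.51 log units; beyond the scatter), and the change to compound 3 is an at least 2.9-fold lower number from compound 1 to compound 3 (0.47 log units; beyond the scatter); both concern the group on the saturated chain carbon bound to an oxygen on the aromatic ring.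

Compound 4 `NNC(=O)c1cc2ccc(OCc3cccc(Br)c3)cc2oc1=O` is not yet measured. It differs from compound 2 at the other end of the core: amino in place of 2-hydroxyethyl on an amide-type nitrogen. For the measured compounds named here, none of the measured steps touches the amide-type nitrogen, so there is no measured step that bears on this change. The expectation for compound 4 is therefore a step within the scatter, a 1.0-fold lower number from compound 2 to compound 4 (0.01 log units; within the scatter), in this assay. Compound 4 is estimated to give 30000 nM, with a range from 10000 nM to 100000 nM.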

Compound 4, half-maximal inhibitory concentration: > 100000 nM
Compound 4 ended at the assay's limit; the forecaster's own chance of this, stated with the estimate: 25%; at least 3.3-fold (0.52 log units) between middle value and limit.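

In this assay putting amino in place of 2-hydroxyethyl produces an at least 3.2-fold higher number from compound 2 to compound 4 (0.51 log units; beyond the scatter) with the 3-bromophenyl group held fixed, so the group on the amide-type nitrogen matters in this series. The earlier compounds shown here varied only the group at the other end of the core, and they could not show that the 3-bromophenyl group alone is not enough to keep a measurable number. Compound 4 stands at a limit of the assay, so the full size of this step cannot be read: the limit of > 100000 nM in this assay, at which 2 of the 4 values shown sit.

On these data alone, it stays open whether a plain ethyl group, a longer chain such as 3-hydroxypropyl, or a 2-aminoethyl group on the same nitrogen would keep the number of compound 2. Also open, as far as these compounds go, is whether amino would do the same alongside the 4-nitrophenyl group of compound 3.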